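A few compounds are considered here, and "the series" means these few. Any claim that something is new, unique, unknown or untested is made for them only; others in the source may bear on it.

Compound 1 `CCN1CCN(c2ccc(S(=O)(=O)Oc3cccc(OC)c3)cc2)C1=O` and compound 2 `CCN1CCN(c2ccc(S(=O)(=O)Oc3cccc(F)c3)cc2)C1=O` share one core and differ in a single spot. In a functional assay on HT-29 cells (Homo sapiens) for antiproliferative activity, read by sulforhodamine B assay, with a stated time of 48 h (a lower number here means a stronger inhibitor, a higher number a weaker inhibitor), compound 1 gives 22000 nM. For compound 2 this assay reports only a limit, > 100000 nM, a boundary of the measurement rather than a number. The change between the two is fluoro in place of methoxy on an aromatic carbon. It brought an at least 4.5-fold higher number from compound 1 to compound 2 (0.65 log units; beyond the scatter), a shift that runs up against (the limit of > 100000 nM in this assay, at which 1 of the 3 values shown sits).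

Compound 3 `CCCN1CCN(c2ccc(S(=O)(=O)Oc3ccc(OC)cc3)cc2)C1=O` carries a different core; how that core differs from the core of compound 1 is not broken down here. In this assay compound 3 gives 16000 nM, and set beside compound 1 the two numbers lie within the usual scatter, so no order between them is claimed.

Compound 4 `CCCN1CCN(c2ccc(S(=O)(=O)Oc3ccc(F)cc3)cc2)C1=O` has not yet been measured. It stands to compound 3 as compound 2 stands to compound 1: fluoro in place of methoxy on an aromatic carbon. The surroundings are not word for word the same, since in compound 1 the group sits meta to a large group while in compound 3 it sits para to a large group, so this counts as the same kind of change rather than the same change.

The expectation rests on compound 3 giving 16000 nM and on the earlier change having brought an at least 4.5-fold higher number from compound 1 to compound 2 (0.65 log units; beyond the scatter). A step of similar size is expected, a 5.6-fold higher number from compound 3 to compound 4 (0.75 log units; beyond the scatter). Compound 4 is therefore estimated at 90000 nM, somewhere from 40000 nM to 200000 nM, with a real chance that this assay again reports only a limit.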

Compound 4, half-maximal inhibitory concentration: 23000 nM
Beside the measured number, compound 4's estimate is 3.9-fold (0.59 log units) above it; measured number outside the range, below it.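

In this assay, fluoro in place of methoxy gave a 1.4-fold higher number from compound 3 to compound 4 (0.16 log units; within the scatter), so on the core of compound 3 the swap produced no shift that can be told apart from the ordinary spread of repeated measurements. As far as these compounds go, the same kind of change therefore did not carry over at the same size from one core to the other: the same change on two cores in this assay, an at least 4.5-fold higher number (0.65 log units; beyond the scatter) from compound 1 to compound 2 and a 1.4-fold higher number (0.16 log units; within the scatter) from compound 3 to compound 4, at least 3.1-fold (0.49 log units) apart, beyond the scatter of two such steps Compound 2 is reported only as a limit, > 100000 nM, so the true size of the earlier step stays unknown, and these two pairs alone do not show whether the core or the place of the group on the ring sets the gap between the steps.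

Left open is how the swap would behave with the group in one and the same place on both cores, which would separate those two differences. Also open, from the compounds shown here alone, is whether another group at that spot, such as chloro, trifluoromethyl or an amine, or a longer chain on the core, would move the number in this assay in either direction.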